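The source may hold more compounds than are shown below. What is called first, only, known or untested is meant among the compounds shown, and "the series" means these compounds.

In a functional assay on MDA-MB-231 cells (Homo sapiens) for antiproliferative activity, read by MTT assay, with a stated time of 72 h (on this read-out higher numbers stand for weaker inhibition and lower numbers for stronger inhibition), compound 1 `COc1cc(CCc2ccc(F)cc2)cc(OC)c1O` gives > 25000 nM, which is a limit of the assay and not a number. Compound 2 `COc1cc(CCc2ccc(Br)cc2)cc(OC)c1O` gives > 25000 nM, again a limit and not a number. Compound 2 thus stands at the limit of > 25000 nM in this assay, at which 2 of the 2 values shown sit. Compound 3 `COc1cc(CCc2ccc([N+](=O)[O-])cc2)cc(OC)c1O` differs from compound 2 by nitro in place of bromo on an aromatic carbon, with nitro in place of bromo on an aromatic carbon. Within the data shown here, the only measured step bearing on this position is a step that the two limits leave unreadable from compound 1 to compound 2, another exchange at the same place, and its size cannot be read. It therefore offers no support for expecting a change beyond the scatter in this assay, in either direction, and another limit is the likeliest outcome. The expected change is a number no higher from compound 2 to compound 3 (the limit leaves the size open). The estimate for compound 3 is 25000 nM, with an expected range from 10000 nM to 50000 nM.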

Compound 3, half-maximal inhibitory concentration: 8050 nM
Beside the measured number, compound 3's estimate is 3.1-fold (0.49 log units) above it, and the stated range ends above it.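

In this assay, this position is no longer silent: nitro in place of bromo gives an at least 3.1-fold lower number from compound 2 to compound 3 (0.49 log units; beyond the scatter), and nitro in place of fluoro gives an at least 3.1-fold lower number from compound 1 to compound 3 (0.49 log units; beyond the scatter). Both steps are lower bounds on the size of the change, since each starts from a limit and not a number, and compound 2 shows how that limit stands: the limit of > 25000 nM in this assay, at which 2 of the 3 values shown sit. The exchange between the two halogens cannot be read, so the result separates nitro from fluoro and bromo but does not order those two.

On these data alone, whether an amine, a nitrile or a carboxylic acid at the same place would also bring the number down remains open, so it cannot be said what about nitro matters here. Also open, as far as these compounds go, is whether nitro would have the same effect elsewhere on the shared core.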